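The source may report more compounds than this note shows. Statements on the series, on what has been measured and on what is new or still open speak of the compounds shown alone.

Measured compounds:
compound 1 `O=C(Nc1ccc(Oc2ccc(-c3nccs3)cc2)cc1)Nc1cc(Br)cc(C(F)(F)F)c1` — 72.8%
compound 2 `O=C(Nc1ccc(Oc2ccc(-c3nccs3)cc2)cc1)Nc1ccc(F)c(Cl)c1` — 43.9%
compound 3 `O=C(Nc1ccc(Oc2ccc(-c3ncc[nH]3)cc2)cc1)Nc1cc(Br)cc(C(F)(F)F)c1` — -13.6%

All three were tested in a functional assay on MDA-MB-231 cells (Homo sapiens) for inhibition, read by MTT assay and WST assay, with a stated time of 72 h, tested at 10 uM; on this read-out lower numbers stand for less inhibition of growth and higher numbers for more inhibition of growth at the one concentration tested. Compound 1 gives the highest of the three numbers, and compound 3 the lowest, with compound 2 between them.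

Two changes separate these compounds. The first, (3-chloro-4-fluorophenyl in place of 3-bromo-5-(trifluoromethyl)phenyl on an amide-type nitrogen), lowers the read-out by a number 28.9 percentage points lower from compound 1 to compound 2 (beyond the scatter). The second, (1H-imidazol-2-yl in place of 1,3-thiazol-2-yl on an aromatic carbon), is the difference between the two cores and produces a much larger drop of a number 86.4 percentage points lower from compound 1 to compound 3 (beyond the scatter); compound 3 shows essentially no growth inhibition at the concentration tested.

Compound 4 `O=C(Nc1ccc(Oc2ccc(-c3ncc[nH]3)cc2)cc1)Nc1ccc(F)c(Cl)c1` has not yet been measured. Within the data shown here, it carries the core of compound 3 and differs from it by 3-chloro-4-fluorophenyl in place of 3-bromo-5-(trifluoromethyl)phenyl on an amide-type nitrogen, which is the same change as the one from compound 1 to compound 2, at the same place in the molecule. From compound 1 to compound 2 that change cost a modest step. Compound 3, however, already sits at a value that means no measurable inhibition, so there is little room for a further drop of the same size; the expectation is therefore that the step from compound 3 to compound 4 in this assay will be smaller than the earlier one, roughly a number 1.6 percentage points higher from compound 3 to compound 4 (within the scatter), resting on compound 3 at -13.6% and on the earlier step of a number 28.9 percentage points lower from compound 1 to compound 2 (beyond the scatter).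

Compound 4 is accordingly estimated at -12% in this assay, with a plausible range from -35% to 12%.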

Compound 4, percent growth inhibition at one concentration: 4.2%
Beside the measured number, compound 4's estimate is 16.2 percentage points below it; measured number inside the range.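

In this assay, the change to 3-chloro-4-fluorophenyl on the amide-type nitrogen gives a number 17.8 percentage points higher from compound 3 to compound 4 (beyond the scatter), so on the core of compound 3 the number rises, whereas on the core of compound 1 the same change lowered it, and neither the size nor the direction of the step carries over from one core to the other: the same change on two cores in this assay, a number 28.9 percentage points lower (beyond the scatter) from compound 1 to compound 2 and a number 17.8 percentage points higher (beyond the scatter) from compound 3 to compound 4, 46.7 percentage points apart, beyond the scatter of two such steps

The other change, 1H-imidazol-2-yl in place of 1,3-thiazol-2-yl, lowers the number with either aryl group, giving a number 39.7 percentage points lower from compound 2 to compound 4 (beyond the scatter), so its direction holds in both pairs while its size does not: the same change on two cores in this assay, a number 86.4 percentage points lower (beyond the scatter) from compound 1 to compound 3 and a number 39.7 percentage points lower (beyond the scatter) from compound 2 to compound 4, 46.7 percentage points apart, beyond the scatter of two such steps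

These four compounds form a single square of two changes, read at one concentration in one cell line, so they show that the two changes do not simply add up here but do not show why, nor how far this holds for other compounds in the series.

The compounds shown leave open how a plain phenyl or a methoxy-bearing phenyl on the amide-type nitrogen would behave on each core. They also leave open whether an amine or a carboxylic acid in place of the 1,3-thiazol-2-yl group would keep any growth inhibition.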